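Shortening the Acid Chain in Two Thromboxane Receptor Inhibitor Series

The source may report more compounds than this note shows. Statements on the series, on what has been measured and on what is new or still open speak of the compounds shown alone.

Three compounds have been measured in a functional assay on a cell-free system (plasma) for inhibition of thromboxane A2 receptor (Homo sapiens), read by turbidimetry; a lower number here means a stronger inhibitor, a higher number a weaker inhibitor:
compound 1, `Cc1ccc(S(=O)(=O)N[C@H]2CC[C@@H](F)[C@@H]2C/C=C\CCCC(=O)O)cc1`, gives 260 nM;
compound 2, `Cc1ccc(S(=O)(=O)N[C@H]2CC[C@@H](F)[C@@H]2C/C=C\CCC(=O)O)cc1`, gives 1900 nM;
compound 3, `O=C(O)CCCCCC[C@@H]1[C@@H](CNS(=O)(=O)c2ccc(F)cc2)CC[C@H]1F`, gives 6000 nM.

Compound 1 and compound 2 share a core and differ in one place: carboxy in place of carboxymethyl on a saturated chain carbon, two bonds along the chain from a double-bonded chain carbon. This change made the step of a 7.3-fold higher number from compound 1 to compound 2 (0.86 log units; beyond the scatter), so the shorter acid chain gave the weaker inhibitor. Compound 3 has the highest number of the three, and its gap to each of the other two lies beyond the scatter. How the core of compound 3 differs from the core of compound 1 is not broken down here.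

Compound 4, `O=C(O)CCCCC[C@@H]1[C@@H](CNS(=O)(=O)c2ccc(F)cc2)CC[C@H]1F`, has not yet been measured. It differs from compound 3 by carboxy in place of carboxymethyl on a saturated chain carbon, five bonds along the chain from a saturated ring carbon. This is the same kind of change as that from compound 1 to compound 2, but the place differs: there the chain carbon sits two bonds from a double-bonded chain carbon, here five bonds from a saturated ring carbon. In this assay compound 4 is expected to show a step of a 4.2-fold higher number from compound 3 to compound 4 (0.62 log units; beyond the scatter), resting on the earlier step of a 7.3-fold higher number from compound 1 to compound 2 (0.86 log units; beyond the scatter) and on the start given by compound 3 at 6000 nM. The estimate for compound 4 is 25000 nM, with a range from 8000 nM to 80000 nM.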

Compound 4, half-maximal inhibitory concentration: 4700 nM
Compound 4: the middle estimate sits 5.3-fold (0.73 log units) above what was measured; the whole stated range lies above it.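

On the core of compound 3, carboxy in place of carboxymethyl gave a 1.3-fold lower number from compound 3 to compound 4 (0.11 log units; within the scatter) in this assay, so this pair cannot be told apart, whereas the same shortening clearly weakened inhibition on the other core. The change therefore did not carry over from one core to the other in this series, and the two steps differ by more than repeated measurement would explain: the same change on two cores in this assay, a 7.3-fold higher number (0.86 log units; beyond the scatter) from compound 1 to compound 2 and a 1.3-fold lower number (0.11 log units; within the scatter) from compound 3 to compound 4, 9.3-fold (0.97 log units) apart, beyond the scatter of two such steps. For the compounds shown here, with only one pair on each core, this shows that the earlier loss cannot be assumed on another core, but it does not show which feature of the cores accounts for the gap, or whether the same gap would appear at other chain lengths.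

The compounds shown leave open how a longer chain would behave on either core, since each core is represented here by only two chain lengths. They also leave open whether an amide or a tetrazole in place of the carboxylic acid would keep any inhibition on either core.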